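Removing the Acetyl Group from a Simple Aryl Urea

The compounds below may be only part of what the source reports. "The series", "measured", "known", "first", "only" and "open" are said of these compounds alone.

Compound 1, `N#CC1CN1C(=O)Nc1ccc(Cl)cc1Cl`, gives 2500 nM in a functional assay on A549 cells (Homo sapiens) for inhibition; a higher number here means a weaker inhibitor, a lower number a stronger inhibitor.
Compound 2, `CC(=O)c1cccc(NC(=O)N2CC2C#N)c1`, gives 5600 nM.
Compound 3, `CCOC(=O)CNC(=O)N1CC1C#N`, gives 24000 nM.

All three compounds share the same core and differ only in the group carried on the urea nitrogen. Compound 2 stands second highest of the three numbers: compound 1 gives a lower number, and that gap lies beyond the usual scatter, while compound 3 gives a higher number, again beyond the scatter. On these numbers compound 2 is a weaker inhibitor than compound 1 and a stronger one than compound 3.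

Compound 4, `N#CC1CN1C(=O)Nc1ccccc1`, has not yet been measured. It differs from compound 2 in a single place: hydrogen in place of acetyl on an aromatic carbon. Going by the values given here, no pair of measured compounds differs by just this change, so the size of the step can only be guessed. The ring of compound 4 carries nothing at all, whereas compound 1, whose ring carries two groups, gives 2500 nM; this is the only hint, and it points weakly toward a stripped ring giving a somewhat weaker inhibitor.

Compound 4 is therefore expected to give about 8000 nM in this assay, within a range from 2500 nM to 25000 nM. The expected step is a 1.4-fold higher number from compound 2 to compound 4 (0.15 log units; within the scatter), a small move toward a weaker inhibitor, possibly not beyond the scatter.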

Compound 4, half-maximal inhibitory concentration: 9000 nM
Estimate against measurement, compound 4: 1.1-fold (0.05 log units) below; the measured number falls inside the stated range.
By their numbers in this assay, from the lowest: compound 1; then compounds 2 and 4 (each within the scatter of the next); then compound 3.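

Compared in this assay, replacing the acetyl group with hydrogen gives a 1.6-fold higher number from compound 2 to compound 4 (0.21 log units; within the scatter) and this is the only comparison here in which a single place changes. The result shows that on this aromatic carbon, the acetyl group, with its 3 heavy atoms and its carbonyl, can give way to a lone hydrogen atom without a shift that stands clear of ordinary repeat variation, so compound 2 and compound 4 cannot be told apart on this read-out. No measurement of any other property accompanies this pair, so the data offer no explanation for the result.

What the compounds shown leave open is whether a different group on this same aromatic carbon, such as an amine, a carboxylic acid or a longer chain, would move the number beyond the scatter in either direction. Going by these compounds, it also remains open whether swapping acetyl for hydrogen would have the same small effect at another carbon of the ring, since this single pair speaks for one position only.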